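Spiro-isoxazoline benzimidazoles: chloro addition to compound 3

The compounds below may be only part of what the source reports. "The series", "measured", "known", "first", "only" and "open" are said of these compounds alone.

Measured so far:
compound 1, `Fc1cccc(C(F)(F)F)c1-c1ccc2[nH]c(C3=NOC4(CCCCC4)C3)nc2c1`, 0.6 nM
compound 2, `FC(F)(F)c1ccccc1-c1cc(Cl)c2[nH]c(C3=NOC4(CCCCC4)C3)nc2c1`, 3.3 nM
compound 3, `FC(F)(F)c1ccccc1-c1ccc2[nH]c(C3=NOC4(CCOCC4)C3)nc2c1`, 6.7 nM

In a functional assay on HEK293 cells for antagonist activity at transient receptor potential M8 protein (Canis lupus familiaris), read by FLIPR and calcium flux (on this read-out lower numbers stand for stronger inhibition and higher numbers for weaker inhibition), compound 3 gives the highest number of the three: compound 2 is lower by a step beyond the scatter, compound 1 lower still. Compound 4, `FC(F)(F)c1ccccc1-c1cc(Cl)c2[nH]c(C3=NOC4(CCOCC4)C3)nc2c1`, is not yet measured. It differs from compound 3 by chloro in place of hydrogen on an aromatic carbon, ortho to a fused ring and meta to the 2-(trifluoromethyl)phenyl group. Going by the values given here, compound 2 also carries a chloro group, but no pair of measured compounds isolates this change, so no step size can be read from the series. For compound 4 a modest shift toward a lower number is expected, a 1.5-fold lower number from compound 3 to compound 4 (0.17 log units; within the scatter), within or near the scatter. The estimate for compound 4 in this assay is 4.5 nM, range 1.5 nM to 14 nM.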

Compound 4, half-maximal inhibitory concentration: 4 nM
The estimate for compound 4 lay 1.1-fold (0.05 log units) above the measured number, within the range that was stated.
By their numbers in this assay, from the lowest: compound 1; then compounds 2, 4 and 3 (each within the scatter of the next, the first and the last beyond it).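

Chloro in place of hydrogen on this aromatic carbon, ortho to a fused ring, can now be read alone: in this assay it gives a 1.7-fold lower number from compound 3 to compound 4 (0.22 log units; within the scatter) and so stays within the scatter. With the chloro group present, a six-membered non-aromatic ring with a hetero atom in place of one of carbon only gives a 1.2-fold higher number from compound 2 to compound 4 (0.08 log units; within the scatter) and also stays within the scatter. No measurement bears on the reason for either step.

Going by these compounds, whether fluoro, methoxy or nitrile in place of chloro would read the same at this position stays open. So does whether an amine on the six-membered non-aromatic ring would stay within the scatter.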